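One Amide Swap, Tested Twice on Two Cores

The compounds below may be only part of what the source reports. "The series", "measured", "known", "first", "only" and "open" are said of these compounds alone.

In a functional assay on ECa-109 cells (Homo sapiens) for cytotoxicity, read by MTT assay, with a stated time of 72 h (on this read-out lower numbers stand for stronger inhibition and higher numbers for weaker inhibition), compound 2 `COCOc1cc(/C=C/C(=O)OCC(=O)NN2CCOCC2)ccc1OCc1ccccc1` gives 143000 nM. Compound 1 `COCOc1cc(/C=C/C(=O)OCC(=O)Nc2ccc(Cl)cc2)ccc1OCc1ccccc1` differs from it by 4-chlorophenyl in place of morpholin-4-yl on an amide-type nitrogen. In this assay compound 1 gives > 200000 nM, which is a limit of the assay and not a number. The step of an at least 1.3-fold higher number from compound 2 to compound 1 (0.14 log units; that floor lies within the scatter) can therefore only be given as a floor. Compound 3 `O=C(COC(=O)/C=C/c1ccc(O)c(O)c1)NN1CCOCC1` carries the same amide part as compound 2, but the difference between the two cores is not broken down here. In this assay compound 3 gives > 200000 nM, again a limit of the assay. Compound 4 `O=C(COC(=O)/C=C/c1ccc(O)c(O)c1)Nc1ccc(Cl)cc1` differs from compound 3 by 4-chlorophenyl in place of morpholin-4-yl on an amide-type nitrogen, the same kind of change as that from compound 2 to compound 1. Because compound 3 already sits at the limit of > 200000 nM in this assay, at which 2 of the 3 values shown sit, and the measured step of this kind reads an at least 1.3-fold higher number from compound 2 to compound 1 (0.14 log units; that floor lies within the scatter), compound 4 is expected to remain there. The expected step is a step that the limit leaves unreadable from compound 3 to compound 4. Compound 4 is estimated at 260000 nM, most probably reported only as a limit.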

Compound 4, half-maximal inhibitory concentration: 175000 nM
For compound 4 the middle estimate is 1.5-fold (0.17 log units) above the measured one; measured number inside the range.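

In this assay, 4-chlorophenyl in place of morpholin-4-yl on the amide-type nitrogen of the second core gives an at least 1.1-fold lower number from compound 3 to compound 4 (0.05 log units; that floor lies within the scatter). Set beside the earlier step, this shows neither that the change carries over unaltered from one core to the other nor that it behaves differently there: the same change on two cores in this assay, an at least 1.3-fold higher number (0.14 log units; that floor lies within the scatter) from compound 2 to compound 1 and an at least 1.1-fold lower number (0.05 log units; that floor lies within the scatter) from compound 3 to compound 4; the limit leaves it open whether they differ. All it shows is that neither floor reaches beyond the usual scatter, with the values gathered at one limit of the assay: the limit of > 200000 nM in this assay, at which 2 of the 4 values shown sit.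

The compounds shown leave open how other groups on that amide-type nitrogen would read on these two cores, such as a plain phenyl, a piperidin-1-yl group or a chain ending in a carboxylic acid. They also leave open the true size of either step.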